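Methoxy on the phenyl of compound 3

The source may report more compounds than this note shows. Statements on the series, on what has been measured and on what is new or still open speak of the compounds shown alone.

Compound 3 `CC(C)(C)n1ncc(OCc2nnc(-c3ccccc3)o2)c(Cl)c1=O` carries an unsubstituted phenyl on the shared core. In a functional assay on the whole organism for inhibition, with Mythimna separata as the target, with a stated time of 5 days (on this read-out lower numbers stand for an effect already at smaller amounts and higher numbers for an effect only at larger amounts of compound), compound 3 gives 12200 nM and stands at the low end of the three numbers measured. Compound 2 `Cc1ccc(-c2nnc(COc3cnn(C(C)(C)C)c(=O)c3Cl)o2)cc1`, with 4-methylphenyl in that place, gives 19900 nM in this assay; the step of a 1.6-fold lower number from compound 2 to compound 3 (0.21 log units; within the scatter) lies within the scatter. Compound 1 `CC(C)(C)n1ncc(OCc2nnc(-c3ccccc3Cl)o2)c(Cl)c1=O`, with 2-chlorophenyl, gives 61200 nM in this assay; the step of a 5.0-fold lower number from compound 1 to compound 3 (0.70 log units; beyond the scatter) is beyond the scatter, as is a 3.1-fold lower number from compound 1 to compound 2 (0.49 log units; beyond the scatter).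

Compound 4 `COc1ccc(-c2nnc(COc3cnn(C(C)(C)C)c(=O)c3Cl)o2)cc1` is not yet measured. It differs from compound 3 by methoxy in place of hydrogen on an aromatic carbon, sitting on the six-membered aromatic ring of carbon only, para to a large group; cut one bond further out, phenyl becomes 4-methoxyphenyl.

The step that bears on this change most directly is the methyl-to-hydrogen change at the same ring position, which stayed within the scatter. The chloro step concerns a different ring position and a different group and gives only a loose bound. The expected step for compound 4 in this assay is a 1.2-fold higher number from compound 3 to compound 4 (0.09 log units; within the scatter), not clearly beyond the scatter, because a 1.6-fold lower number from compound 2 to compound 3 (0.21 log units; within the scatter) stayed within the scatter. Compound 4 is estimated at 15000 nM in this assay, within 5000 nM to 45000 nM.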

Compound 4, half-maximal effective concentration: 17700 nM
Compound 4: the middle estimate sits 1.2-fold (0.07 log units) below what was measured, and the stated range covers the measured number.
By their numbers in this assay, from the lowest: compounds 3, 4 and 2 (each within the scatter of the next); then compound 1.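

Working notes on the position para to a large group: in this assay, methoxy in place of hydrogen stays within the scatter (a 1.5-fold higher number from compound 3 to compound 4 (0.16 log units; within the scatter)), and methoxy in place of methyl does too (a 1.1-fold lower number from compound 2 to compound 4 (0.05 log units; within the scatter)). Hydrogen, methyl and methoxy at this place therefore cannot be told apart on this read-out, so a group with an oxygen and one hydrogen-bond acceptor leaves the number where a methyl does, and the earlier single comparison at this position now has a second and third one beside it. The 2-chlorophenyl of compound 1 stays set apart from the new compound as well (a 3.5-fold lower number from compound 1 to compound 4 (0.54 log units; beyond the scatter)), a modest step beyond the scatter, but no measurement on hand explains any of these steps.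

Still open, from the compounds shown here alone, is whether an amine, a carboxylic acid or a longer alkoxy chain at this same place would move the number beyond the scatter, or whether the series stays flat there. Also open, going by these compounds, is whether the separate standing of compound 1 belongs to the chloro group itself or to its place on the ring, which a chloro at the place of the methoxy would help to settle.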